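Ester chain extension in a dihydropyrimidinone series at adenosine A3

A few compounds are considered here, and "the series" means these few. Any claim that something is new, unique, unknown or untested is made for them only; others in the source may bear on it.

Measured so far:
compound 1, `CCCOC(=O)C1=C(C)NC(=S)NC1c1ccoc1`: 3%
compound 2, `COC(=O)C1=C(C)N(C)C(=O)NC1c1ccco1`: 9%

Both compounds were run in an assay on membranes from HeLa cells for displacement of a labelled ligand from adenosine receptor A3 (Homo sapiens), read by scintillation counting, with a stated time of 180 min, tested at 1 uM; on this read-out higher numbers stand for more inhibition at the one concentration tested (going by the name of the read-out) and lower numbers for less inhibition. Compound 1 gives 3% and compound 2 gives 9% in this assay. Compound 2 carries the higher of the two numbers, but its gap to compound 1 sits within the scatter of repeated measurements, so the two are not told apart; both show little displacement at the single concentration tested.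

The next compound, compound 3, `CC1=C(C(=O)OCc2ccccc2)C(c2ccco2)NC(=O)N1C`, is not yet measured in this assay. It differs from compound 2 in one place:

phenyl in place of hydrogen on a saturated chain carbon bound to an oxygen next to a carbonyl group

Read one bond further out, the change is methyl to benzyl, methoxy to benzyloxy. For the measured compounds named here, no pair of measured compounds differing in a single place is available, so the size of this step cannot be anchored on a comparison. With both measured values low and close together, the step from compound 2 to compound 3 in this assay is expected to be small, most likely none beyond the scatter in either direction, the expected step being a number 3 percentage points higher from compound 2 to compound 3 (within the scatter). Compound 3 is therefore estimated to give 12%, with a range from -5% to 35%.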

Compound 3, a percentage reported as inhibition, at one concentration (the size of the read-out at that concentration, not a potency): 11%
Compound 3: the middle estimate sits 1 percentage points above what was measured; the measured number falls inside the stated range.
By their numbers in this assay, from the lowest: compounds 1, 2 and 3 (each within the scatter of the next).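

In this assay, for the compounds shown here, phenyl in place of hydrogen on a saturated chain carbon bound to an oxygen next to a carbonyl group gives a number 2 percentage points higher from compound 2 to compound 3 (within the scatter), and this is the only comparison so far that isolates a single place. Read one bond further out, methoxy to benzyloxy adds one six-membered aromatic ring of carbon only at this position, yet compound 2 and compound 3 are not told apart, and compound 3 at 11% still shows little displacement at the one concentration tested. Nothing measured on these compounds speaks to why this step is so small.

Going by these compounds, whether a longer chain, an amine or a carboxylic acid at this position would move the number beyond the scatter remains open, as does whether a substituted phenyl would behave like phenyl itself. Compound 1 differs from compound 2 and compound 3 in more than one place, so its steps to them cannot be read, and what the other positions on the shared core contribute also stays unresolved.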